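The source may hold more compounds than are shown below. What is called first, only, known or untested is meant among the compounds shown, and "the series" means these compounds.

Measured so far in a physicochemical assay for lipophilicity, read by HPLC, at pH 7.5; on this read-out higher numbers stand for higher lipophilicity and lower numbers for lower lipophilicity:

- compound 1 (`CCOc1ccccc1-c1ccc(-c2nc3cnccc3c(N[C@H](CC)C(=O)NS(=O)(=O)C3CC3)c2C#N)cc1`) gives 2.3
- compound 2 (`CCOc1ccccc1-c1ccc(-c2nc3cnccc3c(C[C@H](C)C(N)=O)c2C#N)cc1`) gives 3
- compound 3 (`CCOc1ccccc1-c1ccc(-c2nc3cnccc3c(N[C@H](CC)C(N)=O)c2C#N)cc1`) gives 3

Compound 3 stands level with compound 2 and clear of compound 1. Compound 4 (`CCOc1ccccc1-c1ccc(-c2nc3cnccc3c(N[C@@H]3CCOC3=O)c2C#N)cc1`) carries the next change, (2-oxooxolan-3-yl in place of 1-carbamoylpropyl on a nitrogen on an aromatic ring), with 2-oxooxolan-3-yl in place of 1-carbamoylpropyl on a nitrogen on an aromatic ring. Among the measured compounds shown here, no measured step removes the carbamoyl group, so the support is indirect. The step of no change at the digits printed from compound 2 to compound 3 (within the scatter) swaps 2-carbamoylpropyl for (1-carbamoylpropyl)amino and offers no size to carry over. For the measured compounds named here, the step of a number 0.70 log units higher from compound 1 to compound 3 (beyond the scatter) is the only guide to size, and on that basis a modest upward move is expected in this assay. The expected step is a number 0.50 log units higher from compound 3 to compound 4 (beyond the scatter) in this estimate. For compound 4 the estimated value is 3.5, with an expected range of 3 to 4 overall.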

Compound 4, distribution coefficient: 2.7
Beside the measured number, compound 4's estimate is 0.80 log units above it; the measured number lies below the stated range.
By their numbers in this assay, from the lowest: compound 1; then compounds 4, 2 and 3 (each within the scatter of the next).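

In this assay 2-oxooxolan-3-yl in place of 1-carbamoylpropyl on the nitrogen gives a number 0.30 log units lower from compound 3 to compound 4 (within the scatter) and (2-oxooxolan-3-yl)amino in place of 2-carbamoylpropyl gives a number 0.30 log units lower from compound 2 to compound 4 (within the scatter) on this read-out. A ring with 0 hydrogen-bond donors thus reads level with both open-chain carbamoyl groups at this position. The exchange for the larger cyclopropylsulfonyl-bearing group gives a number 0.40 log units higher from compound 1 to compound 4 (beyond the scatter) and leaves compound 1 apart from compound 4.

As far as these compounds go, how a carboxylic acid or a simple amine on this nitrogen would read remains open. No measurement here accounts for these numbers.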